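The source may report more compounds than this note shows. Statements on the series, on what has been measured and on what is new or still open speak of the compounds shown alone.

Measured so far, in a functional assay on MGC-803 cells (Homo sapiens) for antiproliferative activity, read by MTT assay, with a stated time of 48 h; on this read-out higher numbers stand for weaker inhibition and lower numbers for stronger inhibition:
- compound 1 `O=C(Nc1cccc(CNc2nccnc2Cl)c1)Nc1ccccc1Cl` gives 7130 nM
- compound 2 `O=C(Nc1cccc(CNc2nccnc2Cl)c1)Nc1ccccc1F` gives 6440 nM
- compound 3 `O=C(Nc1cccc(CNc2nccnc2Cl)c1)NC1CCCCC1` reaches only the limit > 40000 nM, so no number is known for it.

Compound 1 holds the highest of the two numbers shown, with compound 2 close by: a 1.1-fold lower number from compound 1 to compound 2 (0.04 log units; within the scatter). Compound 4 `O=C(Nc1cccc(CNc2nccnc2Cl)c1)Nc1ccc(Cl)c(Cl)c1` differs from compound 1 by 3,4-dichlorophenyl in place of 2-chlorophenyl on an amide-type nitrogen. The step from compound 1 to compound 2 shows that swapping one halogen on that ring leaves the number within the scatter. Replacing the ring altogether costs much more: an at least 5.6-fold higher number from compound 1 to compound 3 (0.74 log units; beyond the scatter) and an at least 6.2-fold higher number from compound 2 to compound 3 (0.79 log units; beyond the scatter). Compound 4 keeps an aromatic ring, so the expected change is a 1.2-fold lower number from compound 1 to compound 4 (0.07 log units; within the scatter), with an estimated value for compound 4 of 6000 nM (range 2500 nM to 15000 nM).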

Compound 4, half-maximal inhibitory concentration: 4970 nM
Compound 4: middle estimate off by 1.2-fold (0.08 log units), on the high side; the measured number falls inside the stated range.
By their numbers in this assay, from the lowest: compounds 4, 2 and 1 (each within the scatter of the next). At a limit, above all of these: compound 3.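

In this assay, the aromatic ring on this amide-type nitrogen carries two chlorines in compound 4 rather than one halogen, yet the steps stay within the scatter, with a 1.4-fold lower number from compound 1 to compound 4 (0.16 log units; within the scatter) and a 1.3-fold lower number from compound 2 to compound 4 (0.11 log units; within the scatter). Set against cyclohexyl, 3,4-dichlorophenyl again shows how much an aromatic ring at this position counts, with an at least 8.0-fold lower number from compound 3 to compound 4 (0.90 log units; beyond the scatter). The value of compound 3 is a limit: the limit of > 40000 nM in this assay, at which 1 of the 4 values shown sits.

The compounds shown leave open how a plain phenyl ring, or a ring bearing a methoxy group or an amine, would compare at this position.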